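From piperidin-1-yl to (3-methoxyphenyl)amino on the shared core

This account rests on a few compounds, and the source may have more. Where it says the series, first, only, none or still open, it means among the compounds named here.

Working notes on the series. In a functional assay on ECa-109 cells for inhibition, with ECa-109 cell line (Homo sapiens) as the target, read by sulforhodamine B assay (on this read-out lower numbers stand for stronger inhibition and higher numbers for weaker inhibition), compound 1 `O=C1C(NC2CCCC2)=CC(=O)c2c1nc1n2[C@H]2OC[C@@H](O)[C@H]2OC1` gives > 16000 nM, which is a limit. Compound 2 `O=C1C(N2CCCCC2)=CC(=O)c2c1nc1n2[C@H]2OC[C@@H](O)[C@H]2OC1` gives > 8000 nM, which is also a limit. Among the measured compounds shown here, the standing of compound 2 is thus known only as a limit, and the one other value beside it is a limit too.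

The next change leads to compound 3 `COc1cccc(NC2=CC(=O)c3c(nc4n3[C@H]3OC[C@@H](O)[C@H]3OC4)C2=O)c1`: (3-methoxyphenyl)amino in place of piperidin-1-yl on a double-bonded ring carbon. In words, (3-methoxyphenyl)amino comes in place of piperidin-1-yl on a double-bonded ring carbon.

For the measured compounds named here, the only measured step at this place is a step that the two limits leave unreadable from compound 1 to compound 2, with piperidin-1-yl in place of cyclopentylamino. Going by the values given here, it offers no size to carry over, and no measured compound carries an aromatic group at this place. The expectation therefore starts from compound 2 at its limit of > 8000 nM and remains wide. The expected step is a number no higher from compound 2 to compound 3 (the limit leaves the size open), with modestly stronger inhibition in this assay as the tentative direction. The estimate for compound 3 is 8000 nM, with an expected range of 1500 nM to 30000 nM.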

Compound 3, half-maximal inhibitory concentration: 3340 nM
For compound 3 the middle estimate is 2.4-fold (0.38 log units) above the measured one; the range from low to high includes it.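

In this assay, among the compounds shown here, compound 3 gives 3340 nM, the first value at this place on the shared core that is a number and not a limit, so an aromatic amine here can be read in this assay. The change from piperidin-1-yl to (3-methoxyphenyl)amino gives an at least 2.3-fold lower number from compound 2 to compound 3 (0.37 log units; beyond the scatter), while the exchange of cyclopentyl for 3-methoxyphenyl, which keeps the amine nitrogen, gives an at least 4.7-fold lower number from compound 1 to compound 3 (0.68 log units; beyond the scatter); both steps lie beyond the usual scatter. The full size of the first step stays open because compound 2 is known only as a limit: the limit of > 8000 nM in this assay, at which 1 of the 3 values shown sits.

The step between the two saturated groups cannot be read, and the compounds shown do not separate the contribution of the aromatic ring from that of the methoxy group. Plain phenylamino, a hydroxy or chloro group in place of methoxy on the ring, and benzylamino, with one carbon between the amine nitrogen and the ring, would each test a separate part of this change.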